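Butynyl-linked imidazole and dimethylamine pairs in mice

This account rests on a few compounds, and the source may have more. Where it says the series, first, only, none or still open, it means among the compounds named here.

Two pairs share a butynyl linker and differ at its far end. Compound 1 `COC(=O)N(C)CC#CCn1ccnc1` carries the methyl carbamate. In a functional assay on the whole organism for antagonist activity, with Mus musculus as the target (a higher number here means that more compound is needed for the effect, a lower number that less compound is needed), compound 1 gives only a limit, > 100 mg/kg. Compound 2 `COC(=O)N(C)CC#CCN(C)C` differs from compound 1 by dimethylamino in place of 1H-imidazol-1-yl on a saturated chain carbon bound to a triple-bonded carbon. In this assay compound 2 also gives only a limit, > 30 mg/kg. The step that the two limits leave unreadable from compound 1 to compound 2 is therefore not readable; the two values sit at the limit of > 100 mg/kg in this assay, at which 2 of the 3 values shown sit, and (the limit of > 30 mg/kg in this assay, at which 1 of the 3 values shown sits).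

Compound 3 `O=C1NCCN1CC#CCn1ccnc1` has a different core; how the core of compound 3 differs from that of compound 1 is not broken down here. In this assay compound 3 gives only a limit, > 100 mg/kg.

Compound 4 `CN(C)CC#CCN1CCNC1=O` is not yet measured. It differs from compound 3 by dimethylamino in place of 1H-imidazol-1-yl on a saturated chain carbon bound to a triple-bonded carbon, the same change as between the first two compounds, made at the same place. The expected step is a number no higher from compound 3 to compound 4 (the limit leaves the size open), resting on the unreadable step that the two limits leave unreadable from compound 1 to compound 2. For compound 4 the value in this assay is expected at 100 mg/kg, between 30 mg/kg and 300 mg/kg, most probably reported again as a limit.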

Compound 4, dose for half-maximal effect: > 100 mg/kg
Compound 4: no number, only a limit; the forecaster's own chance of this, stated with the estimate: 85%; the middle value sits exactly at the limit.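

In this assay, compound 3 and compound 4 both give only a limit, so no step can be read between them for dimethylamino in place of 1H-imidazol-1-yl. The compounds shown leave open how large this exchange is on either core, and what dose any of the four compounds needs for a half-maximal effect.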